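This account rests on a few compounds, and the source may have more. Where it says the series, first, only, none or still open, it means among the compounds named here.

Compound 2, `CN1C(=O)C(c2c(F)cccc2F)N(C)c2nc(Nc3ccc(S(N)(=O)=O)cc3)ncc21`, stands at the lower of the two numbers in hand in an assay on Sf9 cells for inhibition of serine/threonine-protein kinase 4 (Homo sapiens), read by luminescence and ADP-Glo, with a stated time of 1 h, in the presence of a further agent that is not named here; a lower number here means a stronger inhibitor, a higher number a weaker inhibitor: compound 2 gives 42 nM, and compound 1, `CN1C(=O)C(c2ccccc2C(F)(F)F)N(C)c2nc(Nc3ccc(S(N)(=O)=O)cc3)ncc21`, gives 56 nM. For the measured compounds named here, the step of a 1.3-fold lower number from compound 1 to compound 2 (0.12 log units; within the scatter) is the only measured step, and it exchanges the aryl group on a saturated ring carbon. Compound 3, `CN1C(=O)C(c2c(F)cccc2F)N(C)c2nc(Nc3ccc(S(=O)(=O)NCC4CC4)cc3)ncc21`, keeps the 2,6-difluorophenyl of compound 2 and differs from it in cyclopropylmethyl in place of hydrogen on a sulfonamide nitrogen. Going by the values given here, no measured step bears on this change: the one step in hand touches a different part of the shared core and says nothing about the sulfonamide nitrogen, and neither measured compound carries any group on that nitrogen. With nothing to lean on, the account expects no step beyond the scatter, in either direction, as a 1.4-fold higher number from compound 2 to compound 3 (0.15 log units; within the scatter). Compound 3 is therefore estimated at 60 nM, with a range from 15 nM to 250 nM that stays wide, since the data give no guidance on substitution at this nitrogen and the number for compound 3 in this assay must be awaited.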

Compound 3, half-maximal inhibitory concentration: 79 nM
Compound 3: middle estimate off by 1.3-fold (0.12 log units), on the low side, and the stated range covers the measured number.
By their numbers in this assay, from the lowest: compounds 2, 1 and 3 (each within the scatter of the next).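

In this assay, the sulfonamide nitrogen, which carries no group in compound 1 or compound 2, now bears cyclopropylmethyl, and the change reads as a 1.9-fold higher number from compound 2 to compound 3 (0.27 log units; within the scatter). For the compounds shown here, this gives the first reading at this position: with the 2,6-difluorophenyl held constant, replacing a hydrogen on the sulfonamide nitrogen with this group of 4 carbon atoms, including a three-membered ring, leaves the number within the scatter of the one for the unsubstituted sulfonamide, so this nitrogen does not have to stay unsubstituted for the compound to remain in the same range. No supporting data accompany these numbers that could explain this outcome, and the step is reported here only as a measured difference.

The compounds shown leave open whether the same holds for other groups on this nitrogen, such as a methyl, a longer chain like n-butyl, a chain ending in an amine or a carboxylic acid, or a second substituent replacing the remaining hydrogen. They also leave open whether cyclopropylmethyl gives a similar step when paired with the 2-(trifluoromethyl)phenyl of compound 1.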